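The source may report more compounds than this note shows. Statements on the series, on what has been measured and on what is new or still open speak of the compounds shown alone.

- Compound 1 `CSc1ccc(/C=C(\C(=O)c2ccc(Br)cc2)S(=O)(=O)Cc2ccc(F)cc2)cc1` gives 50000 nM
- Compound 2 `COc1ccc(/C=C(\C(=O)c2ccc(Br)cc2)S(=O)(=O)Cc2ccc(F)cc2)cc1` gives 25000 nM

Both values come from a functional assay on DU-145 cells (Homo sapiens) for inhibition, read by trypan blue exclusion, with a stated time of 96 h; on this read-out lower numbers stand for stronger inhibition of growth and higher numbers for weaker inhibition of growth. Among the measured compounds shown here, compound 2 can be compared only with compound 1, and the two cannot be told apart: the single measured step is a 2.0-fold lower number from compound 1 to compound 2 (0.30 log units; within the scatter), methoxy in place of methylsulfanyl on an aromatic carbon. Compound 3 `O=C(/C(=C\c1cc([N+](=O)[O-])ccc1F)S(=O)(=O)Cc1ccc(F)cc1)c1ccc(Br)cc1` differs from compound 2 by 2-fluoro-5-nitrophenyl in place of 4-methoxyphenyl on a double-bonded chain carbon bound to a double-bonded chain carbon, with 2-fluoro-5-nitrophenyl in place of 4-methoxyphenyl. That one small step offers little guidance for so large a replacement, so only a modest, uncertain shift towards stronger inhibition is expected in this assay. The estimated change is a 2.5-fold lower number from compound 2 to compound 3 (0.40 log units; beyond the scatter). For compound 3 the expected value is 10000 nM, with an estimated range of 1500 nM to 50000 nM.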

Compound 3, concentration for 50% growth inhibition: > 100000 nM
Compound 3: only a limit was reported; the forecaster's own chance of this, stated with the estimate: 10%; middle value at least 10-fold (1.00 log units) away from the limit.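

Placing 2-fluoro-5-nitrophenyl on this double-bonded chain carbon weakens growth inhibition, the first clear change in this series: an at least 4.0-fold higher number from compound 2 to compound 3 (0.60 log units; beyond the scatter). The comparison with the methylsulfanyl compound is less decisive, showing an at least 2.0-fold higher number from compound 1 to compound 3 (0.30 log units; that floor lies within the scatter). The result for compound 3 is a limit of the assay and not a number: the limit of > 100000 nM in this assay, at which 1 of the 3 values shown sits.

The new ring differs from 4-methoxyphenyl in more than one way, so the compounds shown leave open whether the fluorine, the nitro group or the loss of methoxy matters most. On these data alone, how a ring bearing an amine or a carboxylic acid would behave here also remains open.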